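A few compounds are considered here, and "the series" means these few. Any claim that something is new, unique, unknown or untested is made for them only; others in the source may bear on it.

Measured compounds in an ADME assay on BHK-21 cells (Mesocricetus auratus) for cytotoxicity, read by MTT assay, with a stated time of 72 h; a lower number here means that less compound is tolerated, a higher number that more compound is tolerated:
compound 1, `NS(=O)(=O)c1ccc(N2N=C(c3ccc(OCc4ccccc4)cc3)CC2c2ccc(F)cc2)cc1`: 60000 nM
compound 2, `NS(=O)(=O)c1ccc(N2N=C(c3ccc(Oc4ccccc4)cc3)CC2c2ccccc2Cl)cc1`: 8000 nM
compound 3, `Cc1cccc(C2CC(c3ccc(OCc4ccccc4)cc3)=NN2c2ccc(S(N)(=O)=O)cc2)c1`: 8000 nM

Compound 3 stands level with compound 2 at the digits given, and together these are the lowest of the three numbers; compound 1 sits well above, the step being a 7.5-fold lower number from compound 1 to compound 3 (0.88 log units; beyond the scatter). Compound 4, `NS(=O)(=O)c1ccc(N2N=C(c3ccc(OCc4ccccc4)cc3)CC2c2ccccc2Cl)cc1`, arises from compound 3 by one change: 2-chlorophenyl in place of 3-methylphenyl on a saturated ring carbon. Within the data shown here, the only measured step that bears on this is the swap of the aryl group on the saturated ring carbon, a 7.5-fold lower number from compound 1 to compound 3 (0.88 log units; beyond the scatter), a modest step beyond the scatter. Compound 2 carries the same 2-chlorophenyl group on its saturated ring carbon and gives 8000 nM in this assay, no different at the digits given from compound 3. From this no shift beyond the scatter is expected, the expected step being no change at the digits printed from compound 3 to compound 4 (within the scatter). Compound 4 is therefore estimated at 8000 nM, with a range from 3000 nM to 25000 nM.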

Compound 4, half-maximal cytotoxic concentration: 12000 nM
Estimate against measurement, compound 4: 1.5-fold (0.18 log units) below, within the range that was stated.
By their numbers in this assay, from the lowest: compounds 2, 3 and 4 (each within the scatter of the next); then compound 1.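

In this assay, 2-chlorophenyl in place of 3-methylphenyl on a saturated ring carbon gives a 1.5-fold higher number from compound 3 to compound 4 (0.18 log units; within the scatter), so these two groups are not told apart at this position. Among these compounds, the change of phenyl to benzyl on an oxygen on an aromatic ring, seen here for the first time on its own, gives a 1.5-fold higher number from compound 2 to compound 4 (0.18 log units; within the scatter), so it too is not resolved with 2-chlorophenyl in place. With 2-chlorophenyl in place of 4-fluorophenyl, the step is a 5.0-fold lower number from compound 1 to compound 4 (0.70 log units; beyond the scatter), so compound 1 now stands apart from two different groups at this position, not only from 3-methylphenyl.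

Nothing shown explains why 4-fluorophenyl stands apart from the other two groups. As far as these compounds go, whether an amine or a carboxylic acid on the aryl group at this position would fall with compound 1 or with compound 4 remains open.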